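The source may hold more compounds than are shown below. What is called first, only, known or untested is meant among the compounds shown, and "the series" means these compounds.

Measured compounds:
- compound 1 `Cc1c(C)c2c(c(C)c1O)CCC(C)(C(=O)N1CCN(c3ncccn3)CC1)O2` gives 23000 nM in a functional assay (brain) for inhibition, with Rattus norvegicus as the target; on this read-out lower numbers stand for stronger inhibition and higher numbers for weaker inhibition
- compound 2 `COc1ccc(CNC(=O)C2(C)CCc3c(C)c(O)c(C)c(C)c3O2)cc1OC` gives 5500 nM in this assay
- compound 3 `Cc1c(C)c2c(c(C)c1O)CCC(C)(CN1CCN(c3ccccn3)CC1)O2` gives 1000 nM in this assay

Compound 3 has the lowest of the three numbers in this assay; its gap to compound 2 and its larger gap to compound 1 both lie beyond the usual scatter of repeated measurements, so on these numbers compound 3 is the strongest inhibitor of the three. Among the measured compounds shown here, compounds 1 and 2 each differ from compound 3 in more than one place, so none of the measured pairs isolates a single structural change, and there is no measured step to lean on.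

Compound 4 `COc1ccc(N2CCN(CC3(C)CCc4c(C)c(O)c(C)c(C)c4O3)CC2)cc1` has not yet been measured. It differs from compound 3 in one place: 4-methoxyphenyl in place of pyridin-2-yl on an amine nitrogen in a ring. Both groups are flat aromatic rings bearing a single hydrogen-bond acceptor, and the rest of the molecule is unchanged. Without a measured step of this kind, the expected size of the change in this assay is small, in no preferred direction, and most likely within the scatter. Compound 4 is therefore expected to give about 900 nM, between 250 nM and 3500 nM, which means an expected step of a 1.1-fold lower number from compound 3 to compound 4 (0.05 log units; within the scatter).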

Compound 4, half-maximal inhibitory concentration: 200 nM
Compound 4: middle estimate off by 4.5-fold (0.65 log units), on the high side; the whole stated range lies above it.
By their numbers in this assay, from the lowest: compound 4; then compound 3; then compound 2; then compound 1.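

In this assay, the aromatic ring on the amine nitrogen of the six-membered ring with two nitrogens proves to be a position where the choice of group counts: 4-methoxyphenyl in place of pyridin-2-yl gives a 5.0-fold lower number from compound 3 to compound 4 (0.70 log units; beyond the scatter). Among the compounds shown here, this is the only measured pair here that differs in one place, so the earlier compounds could not show that this position responds at all, nor that the response favours the 4-methoxyphenyl group. The two groups have the same counts of hydrogen-bond donors and acceptors and neither carries a net charge, so those counts do not separate them, and nothing measured here explains the step.

The swap changes two things at once, the ring nitrogen of pyridin-2-yl becoming carbon and a methoxy group being added, so a plain phenyl group at this position would be needed to tell these two changes apart. Also open, going by these compounds, is whether other groups on the same nitrogen, such as 4-chlorophenyl or 4-hydroxyphenyl, would give lower or higher numbers than compound 4 does.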